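The compounds below may be only part of what the source reports. "The series", "measured", "known", "first", "only" and "open" are said of these compounds alone.

In an ADME assay on L929 cells (Mus musculus) for cytotoxicity, read by resazurin assay, with a stated time of 72 h (on this read-out higher numbers stand for weaker inhibition and lower numbers for stronger inhibition), compound 1 (`O=C(/C=C/c1ccc2c(c1)B(O)OC2)c1ccc(C(F)(F)F)cc1`) gives > 10 ug/mL, which is a limit of the assay and not a measured number. Compound 2 (`COc1ccc(C(=O)/C=C/c2ccc3c(c2)B(O)OC3)cc1`) gives > 10 ug/mL, which is also only a limit. Compound 2 therefore has no exact position on this scale, and it shares (the limit of > 10 ug/mL in this assay, at which 2 of the 2 values shown sit). Compound 3 (`CC(=O)Nc1ccc(C(=O)/C=C/c2ccc3c(c2)B(O)OC3)cc1`) carries acetamido in place of methoxy on an aromatic carbon, para to a large group: acetamido in place of methoxy on an aromatic carbon.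

Within the data shown here, the one measured step that bears on this change is a step that the two limits leave unreadable from compound 1 to compound 2, which also replaces one group on an aromatic carbon with another. Its size cannot be read, so it offers no measured size or direction to carry forward. With only the limit of > 10 ug/mL in this assay, at which 2 of the 2 values shown sit, to go on, no step beyond the scatter is expected in this assay, and the assay may well report only a limit again. The expected change is a step that the limit leaves unreadable from compound 2 to compound 3. For compound 3, the estimated value is 15 ug/mL, with an expected range from 6 ug/mL to 40 ug/mL.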

Compound 3, half-maximal inhibitory concentration: > 10 ug/mL
Compound 3 was reported as a limit; the forecaster's own chance of this, stated with the estimate: 80%; the middle value is on the limit's open side.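

In this assay compound 3 gives > 10 ug/mL, which is a limit of the assay and not a measured number. Compound 1 and compound 2 also stand only as limits, and no step among these three compounds can be read. Still open is whether trifluoromethyl, methoxy or acetamido on the aromatic carbon changes the value at all, with all results sitting at one limit: the limit of > 10 ug/mL in this assay, at which 3 of the 3 values shown sit.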